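This account rests on a few compounds, and the source may have more. Where it says the series, first, only, none or still open, it means among the compounds named here.

In a toxicity assay on THP-1 cells (Homo sapiens) for inhibition (a higher number here means that more compound is tolerated, a lower number that less compound is tolerated), the measured compounds are these:
- compound 1 `COc1ccc(-c2cnc(NC(=O)c3ccc(F)cc3)n2Cc2ccccc2)cc1` gives > 100000 nM as a limit
- compound 2 `COc1ccc(-c2cnc(NC(=O)c3cccc([N+](=O)[O-])c3)n2C)cc1` gives > 100000 nM as a limit

Compound 1 thus stands at a limit of the assay and has no number, and compound 2 is in the same position. Among the compounds with values here, no step between measured compounds is available to work from.

Compound 3 `COc1ccc(-c2cnc(NC(=O)c3ccc(F)cc3)n2C(C)C)cc1` carries isopropyl in place of benzyl on an aromatic nitrogen, counted as isopropyl in place of benzyl on an aromatic nitrogen and otherwise matches compound 1.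

In this assay no step beyond the scatter is expected for compound 3 because the limit of > 100000 nM in this assay, at which 2 of the 2 values shown sit, gives compound 1 and compound 2 no lower value to point to. The expected change is a number no higher from compound 1 to compound 3 (the limit leaves the size open) and it remains only an estimate. For compound 3 the estimated value is 100000 nM with an expected range from 40000 nM to 200000 nM and a report as a limit is likely.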

Compound 3, half-maximal cytotoxic concentration: > 50000 nM
Compound 3: a limit, no number; the forecaster's own chance of this, stated with the estimate: 85%; the middle value lies beyond the limit too.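

In this assay compound 1 gives > 100000 nM, a limit. Compound 3 gives > 50000 nM, also a limit, so no step can be read between compound 1 and compound 3. The compounds shown leave open what concentration, if any, reaches the half-maximal cytotoxic effect, and whether swapping benzyl for isopropyl changes it.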